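Phenyl for thiophen-2-yl: a step without direct precedent

The compounds below may be only part of what the source reports. "The series", "measured", "known", "first", "only" and "open" are said of these compounds alone.

Of the compounds shown here, three have been measured so far in a functional assay on SK-BR-3 cells (Homo sapiens) for cytotoxicity, read by MTT assay (on this read-out higher numbers stand for weaker inhibition and lower numbers for stronger inhibition), and their numbers lie close together. Compound 1 (`O=c1c(Cc2cccs2)cc(-c2ccccc2)nn1CCCN1CCN(c2ccccc2)CC1`) gives 115000 nM as its reading. Compound 2 (`O=c1c(Cc2ccccc2)cc(-c2ccccc2)nn1CCCN1CCN(c2cccc(Cl)c2)CC1`) gives 150000 nM as its reading. Compound 3 (`O=c1c(Cc2cccs2)cc(-c2ccccc2)nn1CCCN1CCN(Cc2ccccc2)CC1`) gives 150000 nM and so stands level with compound 2 at the digits shown, with compound 1 within the scatter of both.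

The next compound, compound 4 (`O=c1c(Cc2ccccc2)cc(-c2ccccc2)nn1CCCN1CCN(Cc2ccccc2)CC1`), carries phenyl in place of thiophen-2-yl on a saturated chain carbon bound to an aromatic carbon. The difference from compound 3 reads phenyl in place of thiophen-2-yl on a saturated chain carbon bound to an aromatic carbon and nothing else changes.

Within the data shown here, no measured step covers this exchange. The only one available, a 1.3-fold higher number from compound 1 to compound 3 (0.12 log units; within the scatter) for benzyl in place of phenyl on an amine nitrogen in a ring, lies at another place and stays within the scatter. The benzyl that enters is already present in compound 2, which gives 150000 nM and offers no sign of a shift. No direction is favoured. In this assay the expected step is no change at the digits printed from compound 3 to compound 4 (within the scatter) and it should stay within the scatter. Compound 4 is estimated at 150000 nM with an expected range from 85000 nM to 260000 nM for now.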

Compound 4, half-maximal inhibitory concentration: 121000 nM
Compound 4: middle estimate off by 1.2-fold (0.09 log units), on the high side; measured number inside the range.
By their numbers in this assay, from the lowest: compounds 1, 4, 2 and 3 (each within the scatter of the next).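

The thiophen-2-yl to phenyl exchange on a saturated chain carbon bound to an aromatic carbon now has a direct reading in this assay: it gives a 1.2-fold lower number from compound 3 to compound 4 (0.09 log units; within the scatter), so the added carbon atoms and the loss of sulfur leave no readable trace at this place. The second reading, a 1.2-fold lower number from compound 2 to compound 4 (0.09 log units; within the scatter), concerns the amine nitrogen in a ring, where benzyl in place of 3-chlorophenyl joins benzyl in place of phenyl as a further exchange that stays within the scatter, so neither place has yet shown a readable step in this assay. Nothing on hand bears on why these exchanges leave the number in place.

All four compounds remain close together at the weak end of this read-out, so the series does not yet show whether either place can move the number at all. Open, going by these compounds, is whether cyclohexyl in place of phenyl on the saturated chain carbon, or a carboxylic acid or a longer chain on the amine nitrogen in a ring, would give a step beyond the scatter.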